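Compound 4 as an aryl swap on the amide-type nitrogen

This account rests on a few compounds, and the source may have more. Where it says the series, first, only, none or still open, it means among the compounds named here.

Compound 3 `COc1cc(-c2nn(-c3cccc(NC(=O)Nc4ccc(Cl)c(Cl)c4)c3)cc2-c2ccncc2)ccc1Cl` stands lowest of the two numbers in a functional assay on COLO 205 cells (Homo sapiens) for inhibition, read by sulforhodamine B assay, with a stated time of 48 h (a lower number here means that less compound is tolerated, a higher number that more compound is tolerated), with 3140 nM. Its nearest neighbour, compound 2 `COc1cc(-c2nn(-c3cccc(NC(=O)c4cccc(C(F)(F)F)c4)c3)cc2-c2ccncc2)ccc1Cl`, gives 24800 nM in this assay. The step of a 7.9-fold lower number from compound 2 to compound 3 (0.90 log units; beyond the scatter) changes two things at once, the carbonyl substituent and the group behind it, so it does not isolate an aryl swap alone. Compound 1 `O=C(Nc1cccc(-n2cc(-c3ccncc3)c(-c3ccc(Cl)c(O)c3)n2)c1)Nc1cccc(C(F)(F)F)c1` reaches only the limit > 32500 nM in this assay. Compound 4 `COc1cc(-c2nn(-c3cccc(NC(=O)Nc4cccc(C(F)(F)F)c4)c3)cc2-c2ccncc2)ccc1Cl` differs from compound 3 by 3-(trifluoromethyl)phenyl in place of 3,4-dichlorophenyl on an amide-type nitrogen, and thereby carries the same 3-(trifluoromethyl)phenyl on the amide-type nitrogen as compound 1. Among the measured compounds shown here, no measured step covers this exact change. Given (the limit of > 32500 nM in this assay, at which 1 of the 3 values shown sits), the expected step of a 3.8-fold higher number from compound 3 to compound 4 (0.58 log units; beyond the scatter) is toward a higher number for compound 4. Compound 4 is estimated at 12000 nM, within 3500 nM to 32500 nM.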

Compound 4, concentration lethal to 50% of the cells: 3430 nM
For compound 4 the middle estimate is 3.5-fold (0.54 log units) above the measured one, and the stated range ends above it.
By their numbers in this assay, from the lowest: compounds 3 and 4 (each within the scatter of the next); then compound 2. At a limit, above all of these: compound 1.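

In this assay, 3-(trifluoromethyl)phenyl in place of 3,4-dichlorophenyl on the amide-type nitrogen gives a 1.1-fold higher number from compound 3 to compound 4 (0.04 log units; within the scatter), so these two aryl groups cannot be told apart at this position. With the 3-(trifluoromethyl)phenyl held constant, (3-(trifluoromethyl)phenyl)amino in place of 3-(trifluoromethyl)phenyl on the carbonyl carbon gives a 7.2-fold lower number from compound 2 to compound 4 (0.86 log units; beyond the scatter), isolating the change at the carbonyl carbon. Methyl in place of hydrogen on the oxygen gives an at least 9.4-fold lower number from compound 1 to compound 4 (0.97 log units; beyond the scatter), a step that rests on a limit and not on a number: the limit of > 32500 nM in this assay, at which 1 of the 4 values shown sits.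

As far as these compounds go, what an aryl group bearing an amine or a carboxylic acid would give on the amide-type nitrogen stays open. So does the effect of a longer chain in place of the methyl on the oxygen.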